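This account rests on a few compounds, and the source may have more. Where it says the series, first, only, none or still open, it means among the compounds named here.

Measured compounds:
Compound 1 `Cn1c(N2N=C(c3ccccc3)CC2c2ccc(Cl)cc2)nc(-c2ccccc2)c(C#N)c1=O`: 3250 nM
Compound 2 `COc1ccc(C2CC(c3ccccc3)=NN2c2nc(-c3ccccc3)c(C#N)c(=O)n2C)cc1`: 1760 nM
Compound 3 `COc1ccc(C2CC(c3ccc(Cl)cc3)=NN2c2nc(-c3ccc(Cl)cc3)c(C#N)c(=O)n2C)cc1`: 35700 nM

In a functional assay on A549 cells (Homo sapiens) for antiproliferative activity, with a stated time of 72 h (on this read-out lower numbers stand for stronger inhibition and higher numbers for weaker inhibition), compound 1 gives 3250 nM and compound 2 gives 1760 nM. The change between them is methoxy in place of chloro on an aromatic carbon and it made the step of a 1.8-fold lower number from compound 1 to compound 2 (0.27 log units; within the scatter). Compound 3 gives 35700 nM in this assay; how its core differs from that of compound 1 is not broken down here. Compound 4 `COc1ccc(C2=NN(c3nc(-c4ccc(Cl)cc4)c(C#N)c(=O)n3C)C(c3ccc(OC)cc3)C2)cc1` has not yet been measured. It differs from compound 3 by methoxy in place of chloro on an aromatic carbon, the same change as from compound 1 to compound 2. The step from compound 3 to compound 4 in this assay is expected to be about a 1.6-fold lower number from compound 3 to compound 4 (0.21 log units; within the scatter), resting on compound 1 and compound 2, whose step was a 1.8-fold lower number from compound 1 to compound 2 (0.27 log units; within the scatter). Compound 4 is therefore estimated at 22000 nM, between 8000 nM and 60000 nM.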

Compound 4, half-maximal inhibitory concentration: 39700 nM
Beside the measured number, compound 4's estimate is 1.8-fold (0.26 log units) below it; low and high end bracket the measured number.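

In this assay, 4-methoxyphenyl in place of 4-chlorophenyl gives a 1.1-fold higher number from compound 3 to compound 4 (0.05 log units; within the scatter), so on this core, as on the core of compound 1, the change stays within the usual scatter. The two steps do not differ measurably between the cores: the same change on two cores in this assay, a 1.8-fold lower number (0.27 log units; within the scatter) from compound 1 to compound 2 and a 1.1-fold higher number (0.05 log units; within the scatter) from compound 3 to compound 4, 2.1-fold (0.31 log units) apart, within the scatter of two such steps. This shows that the lack of a clear effect carried over from one core to the other, but it does not show that the change would behave the same way on other cores, and two pairs could not reveal a small dependence on the core.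

The compounds shown leave open whether an amine, a carboxylic acid or a longer alkoxy chain at this place would move the number beyond the scatter.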